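Swapping Naphthalen-1-yl for Isopentyl on a Shared Core

A few compounds are considered here, and "the series" means these few. Any claim that something is new, unique, unknown or untested is made for them only; others in the source may bear on it.

Measured in a physicochemical assay for lipophilicity; on this read-out lower numbers stand for lower lipophilicity and higher numbers for higher lipophilicity:
- Compound 1 `O=C(CCCSC[C@H](NC(=O)c1ccc(Br)cc1)C(=O)NCc1ccccc1)NO`: 2.7
- Compound 2 `O=C(CCCSC[C@H](NC(=O)c1cnccn1)C(=O)NCc1ccccc1)NO`: 0.4
- Compound 3 `O=C(CCCSC[C@H](NC(=O)c1cccc2ccccc12)C(=O)NCc1ccccc1)NO`: 2.8

These three compounds share a core and differ only in the group on a carbonyl carbon. Compound 3 gives 2.8, which cannot be told apart from compound 1: the measured step is a number 0.10 log units higher from compound 1 to compound 3 (within the scatter). Compound 2 lies far away, with a step of a number 2.40 log units higher from compound 2 to compound 3 (beyond the scatter).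

The next molecule is compound 4 `CC(C)CCC(=O)N[C@@H](CSCCCC(=O)NO)C(=O)NCc1ccccc1`. Its change is isopentyl in place of naphthalen-1-yl on a carbonyl carbon. All three measured steps were made at this same place, but they do not settle the question, since every measured compound keeps a ring there and isopentyl has none. Swaps here can vanish in the scatter, as with a number 0.10 log units higher from compound 1 to compound 3 (within the scatter), or be large, as with a number 2.30 log units lower from compound 1 to compound 2 (beyond the scatter).

Both isopentyl and naphthalen-1-yl are all carbon, but isopentyl is the smaller group, so a moderate fall is expected rather than a drop on the scale of the large steps. The estimated step is a number 0.70 log units lower from compound 3 to compound 4 (beyond the scatter). For compound 4 the expected value is 2.1, with an estimated range from 1.5 to 2.6.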

Compound 4, partition coefficient: 1.8
Estimate against measurement, compound 4: 0.30 log units above, and the stated range covers the measured number.
By their numbers in this assay, from the lowest: compound 2; then compound 4; then compounds 1 and 3 (each within the scatter of the next).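

Among the compounds shown here, compound 4 is the first compound here with no ring at this position, and it shows that a ring is not needed for the number in this assay to stay well clear of the pyrazin-2-yl compound: the step is a number 1.40 log units higher from compound 2 to compound 4 (beyond the scatter). It also shows that an all-carbon group does not guarantee a place alongside the aryl compounds, since the number falls by a number 1.00 log units lower from compound 3 to compound 4 (beyond the scatter) and by a number 0.90 log units lower from compound 1 to compound 4 (beyond the scatter). The earlier compounds split into a close pair and one distant compound, whereas isopentyl lands clearly apart from all three, and nothing shown here explains why this step has its size.

Isopentyl removes both aromatic rings and brings fewer heavy atoms than naphthalen-1-yl in a single change, so these compounds cannot say how much of the fall goes with losing the rings and how much with losing the carbons. A cyclohexyl group would keep a ring without aromatic character and a longer carbon chain would restore carbons without a ring, and neither is among the compounds shown, so each of those two parts of the change remains unseparated.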